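This account rests on a few compounds, and the source may have more. Where it says the series, first, only, none or still open, it means among the compounds named here.

Notes on the series. In an ADME assay on MCF-10A cells (Homo sapiens) for cytotoxicity, read by MTT assay, with a stated time of 72 h (on this read-out higher numbers stand for weaker inhibition and lower numbers for stronger inhibition), compound 1 `Cc1ccc(-c2ccc(F)cc2)n1-c1ccc(-c2nc3ccc(F)cc3s2)cc1` gives 37800 nM. Compound 3 `COc1ccc2nc(-c3ccc(-n4c(C)ccc4-c4ccc(F)cc4)cc3)sc2c1` differs from compound 1 by methoxy in place of fluoro on an aromatic carbon; in this assay compound 3 gives 38300 nM, a step of a 1.0-fold higher number from compound 1 to compound 3 (0.01 log units; within the scatter). Compound 2 `COc1cc(-c2ccc(C)n2-c2ccc(-c3nc4ccc(F)cc4s3)cc2)cc(OC)c1OC` has another core; the difference between the cores of compound 1 and compound 2 is not broken down here. In this assay compound 2 gives 40000 nM. Compound 4 `COc1ccc2nc(-c3ccc(-n4c(C)ccc4-c4cc(OC)c(OC)c(OC)c4)cc3)sc2c1` remains to be measured; it differs from compound 2 by methoxy in place of fluoro on an aromatic carbon, the same change, at the same place, as that from compound 1 to compound 3. Resting on the step from compound 1 to compound 3 of a 1.0-fold higher number from compound 1 to compound 3 (0.01 log units; within the scatter), the expected step from compound 2 to compound 4 is no change at the digits printed from compound 2 to compound 4 (within the scatter). For compound 4 in this assay the estimate is 40000 nM, expected between 20000 nM and 80000 nM.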

Compound 4, half-maximal inhibitory concentration: 37800 nM
For compound 4 the middle estimate is 1.1-fold (0.02 log units) above the measured one; the range from low to high includes it.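

Going from 6-fluoro-1,3-benzothiazol-2-yl to 6-methoxy-1,3-benzothiazol-2-yl on the core of compound 2 gives, in this assay, a 1.1-fold lower number from compound 2 to compound 4 (0.02 log units; within the scatter). Set beside the earlier step, the change carries from one core to the other with no difference that can be told from the scatter: the same change on two cores in this assay, a 1.0-fold higher number (0.01 log units; within the scatter) from compound 1 to compound 3 and a 1.1-fold lower number (0.02 log units; within the scatter) from compound 2 to compound 4, 1.1-fold (0.03 log units) apart, within the scatter of two such steps. This shows that the change leaves the number unmoved on these two cores in this one assay; it does not show the same on any other core or in any other assay.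

The compounds shown hold only fluoro and methoxy at this place. As far as these compounds go, whether an amine, a carboxylic acid or a longer chain there would move the number stays open.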